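Same atoms, new joining, at the assay limit

The compounds below may be only part of what the source reports. "The series", "measured", "known", "first", "only" and "open" are said of these compounds alone.

Compound 1 `Nc1nc(OCc2cn(-c3n[nH]c4nc(C(F)(F)F)ccc34)nn2)cc(C(F)(F)F)n1` gives > 100000 nM as a limit
Compound 2 `Nc1nc(C(F)(F)F)cc(=O)n1Cc1cn(-c2nn(CCC(F)(F)C(F)(F)C(F)(F)C(F)(F)C(F)(F)C(F)(F)C(F)(F)C(F)(F)F)c3nc(C(F)(F)F)ccc23)nn1` gives > 100000 nM as a limit

In a functional assay on MCF7 cells (Homo sapiens) for cytotoxicity, read by MTT assay, with a stated time of 24 h (a lower number here means a stronger inhibitor, a higher number a weaker inhibitor), compound 2 gives > 100000 nM as a limit of the assay, not a number. Neither measured compound yields a number (the limit of > 100000 nM in this assay, at which 2 of the 2 values shown sit). Compound 3 (`Nc1nc(OCc2cn(-c3nn(CCC(F)(F)C(F)(F)C(F)(F)C(F)(F)C(F)(F)C(F)(F)C(F)(F)C(F)(F)F)c4nc(C(F)(F)F)ccc34)nn2)cc(C(F)(F)F)n1`) keeps the atoms of compound 2 but joins them differently (a group of 12 heavy atoms (5 carbon, 3 nitrogen, 1 oxygen, 3 fluorine; one six-membered aromatic ring with 2 hetero atoms) in place of a group of 12 heavy atoms (5 carbon, 3 nitrogen, 1 oxygen, 3 fluorine; one six-membered aromatic ring with 2 hetero atoms), on a saturated chain carbon bound to an aromatic carbon), with (2-amino-6-(trifluoromethyl)pyrimidin-4-yl)oxy entering on a saturated chain carbon bound to an aromatic carbon. Compound 1, which carries that entering group, gives > 100000 nM as a limit as well. Expected is a step that the limit leaves unreadable from compound 2 to compound 3 in this assay, with no shift beyond the scatter in either direction. For compound 3 the estimate is 120000 nM within an expected range from 50000 nM to 300000 nM in this assay.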

Compound 3, half-maximal inhibitory concentration: > 100000 nM
Compound 3: a limit, no number (the forecaster's own chance of this, stated with the estimate: 80%); the middle value is on the limit's open side.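

Within the data shown here, compound 2 and compound 3 each give only a limit, not a number, so no step between them can be read: the limit of > 100000 nM in this assay, at which 3 of the 3 values shown sit.

From the compounds shown here alone, whether the (2-amino-6-(trifluoromethyl)pyrimidin-4-yl)oxy group of compound 3 changes anything compared with the group it replaces in compound 2 stays open.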